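The source may report more compounds than this note shows. Statements on the series, on what has been measured and on what is new or still open speak of the compounds shown alone.

Working notes on the series. Measured in a functional assay on HepG2 cells (Homo sapiens) for inhibition, read by MTT assay, with a stated time of 72 h; on this read-out higher numbers stand for weaker inhibition and lower numbers for stronger inhibition:

Compound 1 `COc1ccc(/C=C/C(=O)c2c(O)cc(O)cc2OC)cc1` gives 18100 nM.
Compound 2 `COc1cc(O)cc(O)c1C(=O)/C=C/c1ccc([N+](=O)[O-])cc1` gives 41000 nM.
Compound 3 `COc1cc(OC)c(C(=O)/C=C/c2ccccc2OC)c(OC)c1` gives 16300 nM.

The step from compound 1 to compound 2 is nitro in place of methoxy on an aromatic carbon, placed para to a large group, and it gave a 2.3-fold higher number from compound 1 to compound 2 (0.36 log units; beyond the scatter). Compound 4 `COc1cc(OC)c(C(=O)/C=C/c2ccccc2[N+](=O)[O-])c(OC)c1` is unmeasured; it differs from compound 3 by nitro in place of methoxy on an aromatic carbon, here ortho to a large group, so the same kind of change rather than the same one. The difference between the cores of compound 1 and compound 3 is not broken down here. Compound 3 and compound 1 lie within the scatter of each other in this assay.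

Among the compounds with values here, from compound 3 to compound 4 a step of a 2.0-fold higher number from compound 3 to compound 4 (0.31 log units; beyond the scatter) is expected, resting on compound 1 and compound 2 because a 2.3-fold higher number from compound 1 to compound 2 (0.36 log units; beyond the scatter) was the only measured instance of this kind of change. Compound 4 is estimated at 33000 nM, likely between 15000 nM and 75000 nM.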

Compound 4, half-maximal inhibitory concentration: 7900 nM
Compound 4: the middle estimate sits 4.2-fold (0.62 log units) above what was measured, and the stated range ends above it.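

In this assay, nitro in place of methoxy on an aromatic carbon, here ortho to a large group, gave a 2.1-fold lower number from compound 3 to compound 4 (0.31 log units; beyond the scatter). The change does not carry over from one core to the other in this series, not even in direction: the same change on two cores in this assay, a 2.3-fold higher number (0.36 log units; beyond the scatter) from compound 1 to compound 2 and a 2.1-fold lower number (0.31 log units; beyond the scatter) from compound 3 to compound 4, 4.7-fold (0.67 log units) apart, beyond the scatter of two such steps This does not show whether the core or the place of the nitro decides the direction, since the two pairs differ in both and each step rests on a single pair.

The compounds shown leave open whether the nitro step would keep its direction with the group at the same place on both cores. On these data alone, how an amine or a carboxylic acid in that place would compare on either core also remains open.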